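The source may report more compounds than this note shows. Statements on the series, on what has been measured and on what is new or still open speak of the compounds shown alone.

Measured so far:
- compound 1 `CCCCc1ccc(-c2cc(=O)c3c(o2)C(CC)(CC)C(=O)C(CC)=C3O)cc1`: 37 uM
- compound 2 `CCC1=C(O)c2c(oc(-c3ccc(OC(F)(F)F)cc3)cc2=O)C(CC)(CC)C1=O`: 9.95 uM

In a functional assay on KBVIN cells (Homo sapiens) for antiproliferative activity, read by sulforhodamine B assay, with a stated time of 3 days (a higher number here means that more compound is needed for the effect, a lower number that less compound is needed), compound 2 holds the lower of the two numbers, with 9.95 uM, while compound 1 gives 37 uM. The next compound, compound 3 `CCC1=C(O)c2c(oc(-c3ccc(COC)cc3)cc2=O)C(CC)(CC)C1=O`, has methoxymethyl in place of trifluoromethoxy on an aromatic carbon. Going by the values given here, only one measured step bears on this change: a 3.7-fold lower number from compound 1 to compound 2 (0.57 log units; beyond the scatter), which put trifluoromethoxy in place of butyl on an aromatic carbon. It was modest and beyond the scatter. Among the compounds with values here, no measured compound carries methoxymethyl, so the evidence is indirect. Losing trifluoromethoxy is expected to give back part of that step, moving this assay to a higher number by a similar or smaller amount. The expected change is a 2.0-fold higher number from compound 2 to compound 3 (0.30 log units; within the scatter). For compound 3 the estimated value is 20 uM, with an expected range of 8 uM to 50 uM.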

Compound 3, concentration for half-maximal effect: 3.4 uM
Compound 3: the middle estimate sits 5.9-fold (0.77 log units) above what was measured; the whole stated range lies above it.
By their numbers in this assay, from the lowest: compound 3; then compound 2; then compound 1.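

In this assay, trifluoromethoxy turns out not to be needed for the lower number at this position, para to a large group: methoxymethyl in its place gave a 2.9-fold lower number from compound 2 to compound 3 (0.47 log units; beyond the scatter), so the number fell further instead of moving back towards that of the butyl compound. Read against compound 1, the same position shows that methoxy in place of propyl on a saturated chain carbon bound to an aromatic carbon gave an 11-fold lower number from compound 1 to compound 3 (1.04 log units; beyond the scatter), the only large step among these compounds, and compound 3 now holds the lowest number of the three.

On these data alone, whether a longer ether chain, an amine or a carboxylic acid at this position would lower the number further or raise it stays open. Nothing measured here accounts for the order of these three groups.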